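Replacing dimethylamino in compound 3

The source may hold more compounds than are shown below. What is called first, only, known or untested is meant among the compounds shown, and "the series" means these compounds.

Half-lives measured so far in an ADME assay on microsomes from liver (Mus musculus, strain CD-1) for metabolic stability, read by LC-MS, tested at 2 uM (a lower number here means that the compound disappears faster, a higher number that the compound lasts longer), are as follows.
Compound 1 (`CNS(=O)(=O)c1ccccc1Nc1cc(-c2ccc3ccn(C)c3c2)c2nccnc2c1`) 0.2 h
Compound 2 (`CN(Cc1cncnc1)S(=O)(=O)c1ccccc1Nc1cc(-c2ccc3ccn(C)c3c2)c2nccnc2c1`) 0.2 h
Compound 3 (`CN(C)C(=O)c1ccncc1Nc1cc(-c2ccc3ccn(C)c3c2)c2nccnc2c1`) 0.35 h

Compound 3 at 0.35 h lies within the scatter of both other compounds, so the three values cannot be ranked. All three compounds disappear on a similar scale of time in this assay and that is the background for the next compound.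

In compound 4 (`CC(=O)N1CCCC(NC(=O)c2ccncc2Nc2cc(-c3ccc4ccn(C)c4c3)c3nccnc3c2)C1`) (1-acetylpiperidin-3-yl)amino stands in place of dimethylamino on a carbonyl carbon ((1-acetylpiperidin-3-yl)amino in place of dimethylamino on a carbonyl carbon). The same difference, cut one bond further out, reads dimethylcarbamoyl to (1-acetylpiperidin-3-yl)carbamoyl. Among the compounds with values here, no measured step covers a change at this place. Within the data shown here, the one measured step shows no change at the digits printed from compound 1 to compound 2 (within the scatter) when (pyrimidin-5-yl)methyl stands in place of hydrogen on a sulfonamide nitrogen. That step sits at a different place, so it is only weak guidance, but it offers no reason to expect a shift. The expected result is therefore no step beyond the scatter in this assay and the estimated step is a 1.2-fold lower number from compound 3 to compound 4 (0.07 log units; within the scatter) (direction not meaningful at this size). The estimated half-life for compound 4 is 0.3 h (expected range 0.12 h to 0.7 h).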

Compound 4, half-life: 0.4 h
The estimate for compound 4 lay 1.3-fold (0.12 log units) below the measured number; measured number inside the range.
By their numbers in this assay, from the lowest: compounds 1, 2, 3 and 4 (each within the scatter of the next).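

At the place on a carbonyl carbon whose other neighbour is an aromatic carbon, this assay gives a first measured step: (1-acetylpiperidin-3-yl)amino in place of dimethylamino gives a 1.1-fold higher number from compound 3 to compound 4 (0.06 log units; within the scatter). The exchange is a large one in structure, with 10 heavy atoms, one six-membered non-aromatic ring, 1 hydrogen-bond donor and 1 hydrogen-bond acceptor entering where 3 heavy atoms and no ring leave, yet this half-life does not separate the two compounds. No independent measurement bears on the reason for this result.

The compounds shown leave open whether any group at this place can produce a step beyond the scatter in this assay, since only dimethylamino and (1-acetylpiperidin-3-yl)amino can be compared here. They also do not show whether the acetyl group on the piperidine nitrogen matters to the half-life, or whether a free piperidine amine, a morpholine or a chain ending in a carboxylic acid at the same carbonyl carbon would give a half-life that differs from these two.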